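This account rests on a few compounds, and the source may have more. Where it says the series, first, only, none or still open, it means among the compounds named here.

Measured compounds in a functional assay on the whole organism (strain Charles Foster albino) for inhibition, with Rattus norvegicus as the target, read by paw edema, with stated times of 30 min and 3 h, at a dose of 50 mg/kg by the oral route; a lower number here means less inhibition, a higher number more inhibition at the dose given (going by the name of the read-out):
compound 1 `CN(C)c1ccc(C2CC(c3ccncc3)=NN2)cc1` — 0%
compound 2 `CN(C)c1ccc(C2CC(c3ccccn3)=NN2)cc1` — 18%
compound 3 `CN(C)c1ccc(C2CC(c3cccnc3)=NN2c2ccccc2)cc1` — 34%

Compound 3 gives the highest number of the three; compound 2 lies nearest and compound 1 furthest, both gaps beyond the scatter. Compound 4 `CN(C)c1ccc(C2CC(c3cccnc3)=NN2)cc1` is not yet measured. The change from compound 3 to compound 4 is hydrogen in place of phenyl on an amine nitrogen in a ring.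

Within the data shown here, no measured step bears directly on this change: the one measured step, a number 18 percentage points higher from compound 1 to compound 2 (beyond the scatter), concerns the pyridyl group alone. Compound 4 shares its pyridin-3-yl with compound 3 and its unsubstituted ring nitrogen with compounds 1 and 2, which both gave lower numbers. A drop is therefore expected, of uncertain size; the estimated step is a number 19 percentage points lower from compound 3 to compound 4 (beyond the scatter). Compound 4 is estimated at 15%, within 0% to 35%.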

Compound 4, a percentage reported as inhibition, in the whole organism at one dose (the size of the read-out at that dose, not a potency): 22%
Compound 4: the middle estimate sits 7 percentage points below what was measured, and the stated range covers the measured number.
By their numbers in this assay, from the lowest: compound 1; then compounds 2 and 4 (each within the scatter of the next); then compound 3.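

In this assay the ring amine nitrogen now has a direct comparison: hydrogen in place of phenyl gives a number 12 percentage points lower from compound 3 to compound 4 (beyond the scatter) and shows that this position affects the read-out. With hydrogen on that nitrogen, the pyridyl change gives a number 4 percentage points higher from compound 2 to compound 4 (within the scatter) but also a number 22 percentage points higher from compound 1 to compound 4 (beyond the scatter) and thus sets pyridin-4-yl apart from the other two pyridyl groups. Nothing available explains either result.

Open, from the compounds shown here alone, is how an acetyl or a benzyl group on that nitrogen would compare with phenyl. Also open, going by these compounds, is whether the phenyl step holds with pyridin-2-yl or pyridin-4-yl.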